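This account rests on a few compounds, and the source may have more. Where it says the series, first, only, none or still open, it means among the compounds named here.

Measured compounds:
compound 1, `O=C(NC[C@@H]1CCCc2cc(S(=O)(=O)c3cccc(F)c3)ccc21)c1ncc[nH]1`, 15.9 nM
compound 2, `O=S(=O)(c1cccc(F)c1)c1ccc2c(c1)CCC[C@H]2CN1CC(O)C1`, 0.1 nM

In an assay on isolated protein for displacement of a labelled ligand from 5-hydroxytryptamine receptor 6 (Homo sapiens) (a higher number here means a weaker inhibitor, a lower number a stronger inhibitor), compound 2 gives the lowest of the two numbers; its nearest neighbour is compound 1, a much higher one, and the step of a 160-fold lower number from compound 1 to compound 2 (2.20 log units; beyond the scatter) is large and well beyond the scatter. Compound 3, `NCC(=O)NC[C@@H]1CCCc2cc(S(=O)(=O)c3cccc(F)c3)ccc21`, has not yet been measured. It differs from compound 2 by ((aminomethyl)carbonyl)amino in place of 3-hydroxyazetidin-1-yl on a saturated chain carbon bound to a saturated ring carbon. For the measured compounds named here, only one measured step bears on this change: in it, an amide-type substituent at this place was exchanged for the 3-hydroxyazetidin-1-yl ring, and the number fell strongly, a 160-fold lower number from compound 1 to compound 2 (2.20 log units; beyond the scatter). Compound 3 reverses that direction, putting an amide-type substituent, ((aminomethyl)carbonyl)amino, back at the same place, while keeping a basic amine, as compound 2 does. A considerable rise in this assay is therefore expected, though perhaps not the full extent of the step seen from compound 1 to compound 2, because compound 1 gave 15.9 nM with no basic nitrogen. The estimated step is a 50-fold higher number from compound 2 to compound 3 (1.70 log units; beyond the scatter). For compound 3 the expected value is 5 nM, with a range from 1 nM to 30 nM.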

Compound 3, inhibition constant: 0.316 nM
Beside the measured number, compound 3's estimate is 16-fold (1.20 log units) above it, and the stated range ends above it.
By their numbers in this assay, from the lowest: compound 2; then compound 3; then compound 1.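

In this assay the exchange on a saturated chain carbon bound to a saturated ring carbon gives a 3.2-fold higher number from compound 2 to compound 3 (0.50 log units; beyond the scatter) and so shows that an amide-type substituent at this place can sit close to the 3-hydroxyazetidin-1-yl group, although compound 2 keeps the lowest number of the three. Most of the distance between compound 1 and compound 2 is already covered with the carbonyl kept: aminomethyl in place of 1H-imidazol-2-yl on a carbonyl carbon gives a 50-fold lower number from compound 1 to compound 3 (1.70 log units; beyond the scatter) on its own. The high number of compound 1 therefore goes with the 1H-imidazol-2-yl group on the carbonyl carbon and not with the carbonyl-linked amide as such, which the first step alone could not separate.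

Still open, on these data alone, is whether a longer chain such as 2-aminoethyl, or a dimethylamino group in place of the primary amine, would keep the number near that of compound 3 or bring it closer to that of compound 2. Nothing shown here speaks to the reason for either step.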